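A few compounds are considered here, and "the series" means these few. Any claim that something is new, unique, unknown or untested is made for them only; others in the source may bear on it.

Compound 1, `O=C(CCCCc1ccccc1)CC(=O)N[C@H]1CCOC1=O` — 83000 nM
Compound 2, `O=C(CCCCCCc1ccccc1)CC(=O)N[C@H]1CCOC1=O` — 9000 nM
Compound 3, `O=C(CCCCCCCCCCc1ccccc1)N[C@H]1CCOC1=O` — 66000 nM

Of the compounds shown here, three sharing a lactam-bearing core have been measured in a functional assay on PC-3 cells (Homo sapiens) for cytotoxicity, read by sulforhodamine B assay, with a stated time of 5 days; a lower number here means a stronger inhibitor, a higher number a weaker inhibitor. Compound 2 gives 9000 nM, and compound 1 gives 83000 nM; the step of a 9.2-fold higher number from compound 2 to compound 1 (0.96 log units; beyond the scatter) comes from the change (phenyl in place of phenethyl on a saturated chain carbon, four bonds along the chain from a carbonyl carbon). Compound 3 gives 66000 nM; the difference between the cores of compound 2 and compound 3 is not broken down here, so only their two values can be compared, and compound 3 stands within the scatter of compound 1.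

Compound 4, `O=C(CCCCCCCCc1ccccc1)N[C@H]1CCOC1=O`, has not yet been measured in this assay. It differs from compound 3 by phenyl in place of phenethyl on a saturated chain carbon, eight bonds along the chain from a carbonyl carbon. This is the same kind of change as that from compound 2 to compound 1, but not the same: there the place was four bonds along the chain from a carbonyl carbon, here it is eight bonds along the chain from a carbonyl carbon. Within the data shown here, the only precedent is the step of a 9.2-fold higher number from compound 2 to compound 1 (0.96 log units; beyond the scatter), so the expected step is a 2.3-fold higher number from compound 3 to compound 4 (0.36 log units; beyond the scatter), taken as a weaker version of that one because the earlier one reads a 9.2-fold higher number from compound 2 to compound 1 (0.96 log units; beyond the scatter). Compound 4 is therefore expected to give about 150000 nM, with a range from 50000 nM to 500000 nM.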

Compound 4, half-maximal inhibitory concentration: 67000 nM
For compound 4 the middle estimate is 2.2-fold (0.35 log units) above the measured one, within the range that was stated.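

In this assay, putting phenyl in place of phenethyl on a saturated chain carbon, eight bonds along the chain from a carbonyl carbon, gives a 1.0-fold higher number from compound 3 to compound 4 (0.01 log units; within the scatter), so on this core the change leaves the number within the scatter. The same change therefore does not carry over at a fixed size from one core to the other: the same change on two cores in this assay, a 9.2-fold higher number (0.96 log units; beyond the scatter) from compound 2 to compound 1 and a 1.0-fold higher number (0.01 log units; within the scatter) from compound 3 to compound 4, 9.1-fold (0.96 log units) apart, beyond the scatter of two such steps. This does not show what sets the two steps apart, since the cores differ and the place of the change differs as well, four bonds along the chain from a carbonyl carbon in one pair and eight in the other, and two pairs cannot separate these.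

The compounds shown leave open how a longer chain on the core of compound 2 would read in this assay. They also leave open whether an amine or a carboxylic acid at the chain end, in place of phenyl, would give a different number on either core.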